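The source may hold more compounds than are shown below. What is called first, only, known or untested is meant among the compounds shown, and "the series" means these compounds.

Three compounds share one core and differ in the group on the aromatic ring. Compound 1 `Fc1ccc(OCC2=NCCO2)cc1` carries fluoro; in a toxicity assay on the whole organism with Rattus norvegicus as the target, at a dose of 400 mg/kg by the oral route (on this read-out higher numbers stand for a stronger effect at the one dose given and lower numbers for a weaker effect), compound 1 gives 75%. Compound 3 `O=[N+]([O-])c1ccc(OCC2=NCCO2)cc1` carries nitro, and in this assay compound 3 gives 20%. The change fluoro in place of nitro on an aromatic carbon made a number 55 percentage points higher from compound 3 to compound 1 (beyond the scatter). Compound 2 `O=[N+]([O-])c1ccccc1OCC1=NCCO1` also carries nitro; how its core differs from the core of compound 3 is not broken down here. In this assay compound 2 gives 45%. Compound 4 `Fc1ccccc1OCC1=NCCO1` is not yet measured. Among the measured compounds shown here, the change fluoro in place of nitro on an aromatic carbon is the same kind of change as the one between compound 3 and compound 1, but the place differs: ortho to a group of 7 heavy atoms rather than para to a group of 7 heavy atoms. A step of a number 35 percentage points higher from compound 2 to compound 4 (beyond the scatter) is expected, resting on the earlier step of a number 55 percentage points higher from compound 3 to compound 1 (beyond the scatter). Compound 4 is therefore expected to give about 80% in this assay, estimated between 55% and 100%.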

Compound 4, a percentage reported as activity, at one dose (the size of the read-out at that dose, not a potency): 20%
Beside the measured number, compound 4's estimate is 60 percentage points above it; measured number below the stated range.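

With the group ortho to a group of 7 heavy atoms, fluoro in place of nitro on an aromatic carbon gave a number 25 percentage points lower from compound 2 to compound 4 (beyond the scatter). In this assay, the size and even the direction of this change therefore depend on the core, so a step seen on one core cannot simply be carried to the other: the same change on two cores in this assay, a number 55 percentage points higher (beyond the scatter) from compound 3 to compound 1 and a number 25 percentage points lower (beyond the scatter) from compound 2 to compound 4, 80 percentage points apart, beyond the scatter of two such steps This does not show why the two steps part ways, and two pairs say nothing about any further core.

The compounds shown leave open how an amine or a carboxylic acid in place of the nitro would behave on either core. They also leave open whether such groups would follow one of these two steps or neither.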